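A few compounds are considered here, and "the series" means these few. Any claim that something is new, unique, unknown or untested is made for them only; others in the source may bear on it.

Measured in a functional assay on Jurkat cells (Homo sapiens) for inhibition, with a stated time of 24 h; on this read-out higher numbers stand for weaker inhibition and lower numbers for stronger inhibition:
Compound 1 `Clc1ccc(Nc2nnc(-c3c[nH]c4ccccc34)o2)cc1`: 30200 nM
Compound 2 `Clc1cccc(Nc2nnc(-c3c[nH]c4ccccc34)o2)c1`: > 100000 nM, a limit of the assay
Compound 3 `Fc1ccc(Nc2nnc(-c3c[nH]c4ccccc34)o2)cc1`: > 100000 nM, a limit of the assay

Compound 3 has no number, only a limit, and it stands at the limit of > 100000 nM in this assay, at which 2 of the 3 values shown sit. The next structure, compound 4 `c1ccc(CNc2nnc(-c3c[nH]c4ccccc34)o2)cc1`, carries benzyl in place of 4-fluorophenyl on a nitrogen on an aromatic ring.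

For the measured compounds named here, no measured step covers this exchange directly. The nearest evidence is an at least 3.3-fold higher number from compound 1 to compound 2 (0.51 log units; beyond the scatter) and an at least 3.3-fold higher number from compound 1 to compound 3 (0.51 log units; beyond the scatter). Both lie beyond the scatter, and both end at a limit. The remaining comparison, a step that the two limits leave unreadable from compound 2 to compound 3, cannot be read. Of the three compounds, only compound 1 gives a number, so nothing measured points to a clear gain from the benzyl group. In this assay, no large step in either direction is therefore expected, and compound 4 may well be reported only as a limit again. The expected change is an at least 1.2-fold lower number from compound 3 to compound 4 (0.09 log units; that floor lies within the scatter). For compound 4 the estimated value is 80000 nM, with an expected range of 30000 nM to 150000 nM.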

Compound 4, half-maximal inhibitory concentration: > 100000 nM
Compound 4 was reported as a limit; the forecaster's own chance of this, stated with the estimate: 60%; middle value at least 1.2-fold (0.09 log units) from the limit.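

Benzyl in place of 4-chlorophenyl gives an at least 3.3-fold higher number from compound 1 to compound 4 (0.51 log units; beyond the scatter) in this assay, so this exchange on a nitrogen on an aromatic ring also fails to keep the measurable value of compound 1. Like the 3-chlorophenyl of compound 2 and the 4-fluorophenyl of compound 3, the benzyl of compound 4 therefore leaves only a limit of the assay, now with a group that has carbon as its only heavy atoms. The steps from compound 2 and from compound 3 to compound 4 cannot be read, and compound 1 alone gives a number: the limit of > 100000 nM in this assay, at which 3 of the 4 values shown sit.

Going by these compounds, how far compound 2, compound 3 and compound 4 lie beyond that limit stays open, so no order among them can be given. Also open, on these data alone, is whether a 4-bromophenyl or a 2-phenylethyl group at this place would give a number.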